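Propylthio series: hydrazone swap from compound 1 to compound 4

The source may report more compounds than this note shows. Statements on the series, on what has been measured and on what is new or still open speak of the compounds shown alone.

Measured so far:
compound 1 `CCCSc1nc(N/N=C/c2cccnc2)c2nnn(Cc3ccccc3)c2n1` — 38100 nM
compound 2 `CCCSc1nc(N/N=C/c2ccccc2Cl)c2nnn(Cc3ccccc3)c2n1` — 10900 nM
compound 3 `C/C(=N\Nc1nc(SCc2ccccc2)nc2c1nnn2Cc1ccccc1)c1ccccc1O` — 850 nM

In a functional assay on MGC-803 cells (Homo sapiens) for antiproliferative activity, read by MTT assay, with a stated time of 72 h (on this read-out lower numbers stand for stronger inhibition and higher numbers for weaker inhibition), compound 1 gives the highest of the three numbers. Its nearest neighbour is compound 2, reached by a 3.5-fold lower number from compound 1 to compound 2 (0.54 log units; beyond the scatter), a step beyond the scatter; compound 3 lies much further off, at a number a long way below that of compound 1.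

Compound 4 `CCCSc1nc(N/N=C(\C)c2ccccc2O)c2nnn(Cc3ccccc3)c2n1` has not been measured. It differs from compound 1 in one place: a group of 10 heavy atoms (8 carbon, 1 nitrogen, 1 oxygen; one six-membered aromatic ring of carbon only) in place of a group of 8 heavy atoms (6 carbon, 2 nitrogen; one six-membered aromatic ring with 1 hetero atom), on a nitrogen on an aromatic ring

For the measured compounds named here, the one measured step that bears on this is the replacement on the same carbon from compound 1 to compound 2, which lowered the number in this assay by a modest but real margin. Compound 3 carries the same incoming group as compound 4 but differs from it elsewhere, so its value can only be read as showing that this group is compatible with a low number in this assay.

Taken together, a step in the same direction as a 3.5-fold lower number from compound 1 to compound 2 (0.54 log units; beyond the scatter) and somewhat larger is expected, an 11-fold lower number from compound 1 to compound 4 (1.04 log units; beyond the scatter). Compound 4 is therefore estimated at 3500 nM, with a range of 900 nM to 14000 nM.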

Compound 4, half-maximal inhibitory concentration: 2310 nM
The estimate for compound 4 lay 1.5-fold (0.18 log units) above the measured number; low and high end bracket the measured number.
By their numbers in this assay, from the lowest: compound 3; then compound 4; then compound 2; then compound 1.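

In this assay, for the compounds shown here, the exchange gives a 16-fold lower number from compound 1 to compound 4 (1.22 log units; beyond the scatter) within the propylthio series itself, so the incoming group, earlier seen only in compound 3 with a different sulfur substituent, is now tied to a large drop on this core. The comparison with the chlorine-bearing group gives a 4.7-fold lower number from compound 2 to compound 4 (0.67 log units; beyond the scatter) and stays beyond the scatter, so a carbon-only aromatic ring in place of the pyridine ring, which both compounds share, does not alone cover the full step from compound 1. With the incoming group held constant, the step of a 2.7-fold higher number from compound 3 to compound 4 (0.43 log units; beyond the scatter) shows that the ethyl-for-phenyl change on the saturated chain carbon bound to a sulfur also moves the number, though by a modest margin.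

No measurement here offers an explanation for any of these steps. The compounds shown do not separate the contribution of the methyl on the carbon with a double bond to nitrogen from that of the hydroxyl on the aromatic ring, and they leave open whether an amine in place of that hydroxyl, or a longer chain on the sulfur, would keep the number this low.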